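The source may hold more compounds than are shown below. What is called first, only, known or untested is meant among the compounds shown, and "the series" means these compounds.

In an ADME assay on microsomes from liver (Rattus norvegicus) for metabolic stability, read by LC-MS, using NADPH, at 37 degrees C (a lower number here means that the compound disappears faster, a higher number that the compound lasts longer), compound 1 `Cc1oc(-c2ccc(Cl)cc2)nc1CN1CCC(C(=O)NCCCN2C[C@H](C)C[C@H](C)C2)CC1` gives > 0.5 h as a limit and not a number. Compound 2 `Cc1oc(-c2ccc(Cl)c(Cl)c2)nc1CN1CCC(C(=O)NCCCN2C[C@H](C)C[C@H](C)C2)CC1` gives > 0.5 h which is likewise a limit. Within the data shown here, the series so far stands at the limit of > 0.5 h in this assay, at which 2 of the 2 values shown sit, and compound 2 therefore has no exact position. Among the measured compounds shown here, the only measured step is a step that the two limits leave unreadable from compound 1 to compound 2 and it offers no size to carry forward. For the measured compounds named here, compound 3 `Cc1oc(-c2c(Cl)cccc2C(F)(F)F)nc1CN1CCC(C(=O)NCCCN2C[C@H](C)C[C@H](C)C2)CC1` differs by 2-chloro-6-(trifluoromethyl)phenyl in place of 3,4-dichlorophenyl on an aromatic carbon and no measured step covers this exchange. Expected is a number no higher from compound 2 to compound 3 (the limit leaves the size open) with no direction estimated beyond the scatter. Compound 3 is expected at 0.5 h with an estimated range from 0.2 h to 1 h in this assay again.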

Compound 3, half-life: 0.03 h
Compound 3: middle estimate off by 17-fold (1.22 log units), on the high side; measured number outside the range, below it.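

In this assay, the aryl group on this aromatic carbon of the five-membered ring now shows a readable effect on half-life. 2-Chloro-6-(trifluoromethyl)phenyl in place of 3,4-dichlorophenyl gives an at least 16-fold lower number from compound 2 to compound 3 (1.22 log units; beyond the scatter), and in place of 4-chlorophenyl it gives an at least 16-fold lower number from compound 1 to compound 3 (1.22 log units; beyond the scatter). Compound 3 is the first to give a number, while compound 1 and compound 2 each stop at a limit: the limit of > 0.5 h in this assay, at which 2 of the 3 values shown sit.

Still open, as far as these compounds go, is whether the chloro or the trifluoromethyl of the entering group carries this drop. Also open, from the compounds shown here alone, is how a nitrile or a pyridyl ring would read on this carbon.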